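The compounds below may be only part of what the source reports. "The series", "measured", "known", "first", "only" and "open" are said of these compounds alone.

Compound 1 `COc1cc(N(C)CCN(C)C)c(NC(=O)/C=C\C(C)C)cc1Nc1ncc(C#N)c(-c2cn(C)c3ccc(F)cc23)n1`: 185 nM
Compound 2 `CCC/C=C\C(=O)Nc1cc(Nc2ncc(C#N)c(-c3cn(C)c4ccc(F)cc34)n2)c(OC)cc1N(C)CCN(C)C`: 741 nM
Compound 3 `COc1cc(N(C)CCN(C)C)c(NC(=O)/C=C\C(C)C)cc1Nc1nc(C)cc(-c2cn(C)c3ccc(F)cc23)n1`: 9080 nM

Three compounds were measured in a functional assay on A549 cells (Homo sapiens) for antiproliferative activity, read by MTT assay, with a stated time of 72 h (a higher number here means a weaker inhibitor, a lower number a stronger inhibitor), and a fourth, compound 4 `CCC/C=C\C(=O)Nc1cc(Nc2nc(C)cc(-c3cn(C)c4ccc(F)cc34)n2)c(OC)cc1N(C)CCN(C)C`, still awaits measurement there.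

Compound 1 and compound 2 share one core and differ in a single place: propyl in place of isopropyl on a double-bonded chain carbon bound to a double-bonded chain carbon. This change produced a 4.0-fold higher number from compound 1 to compound 2 (0.60 log units; beyond the scatter).

Compound 3 carries a different core; how that core differs from the core of compound 1 is not broken down here. In this assay compound 3 gives 9080 nM, the highest of the three numbers, and the gaps from compound 3 to compound 2 and to compound 1 are both described as beyond the scatter.

Compound 4 is related to compound 3 exactly as compound 2 is to compound 1: propyl in place of isopropyl on a double-bonded chain carbon bound to a double-bonded chain carbon. Going by the values given here, since the change and its place are the same, the step from compound 3 to compound 4 is expected to be of similar size to the earlier one, because a 4.0-fold higher number from compound 1 to compound 2 (0.60 log units; beyond the scatter) is the only guide available; it is expected to come out as a 3.3-fold higher number from compound 3 to compound 4 (0.52 log units; beyond the scatter). On that basis compound 4 is estimated at 30000 nM, with a range from 9000 nM to 90000 nM.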

Compound 4, half-maximal inhibitory concentration: 13300 nM
For compound 4 the middle estimate is 2.3-fold (0.35 log units) above the measured one, and the stated range covers the measured number.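

In this assay, propyl in place of isopropyl on the second core gave a 1.5-fold higher number from compound 3 to compound 4 (0.17 log units; within the scatter), a step that cannot be told apart from the scatter. The same change therefore did not carry over at the same size, and the two steps differ by more than the scatter of two such steps: the same change on two cores in this assay, a 4.0-fold higher number (0.60 log units; beyond the scatter) from compound 1 to compound 2 and a 1.5-fold higher number (0.17 log units; within the scatter) from compound 3 to compound 4, 2.7-fold (0.44 log units) apart, beyond the scatter of two such steps. This shows that, for these two pairs, the size of the step depends on the core it is made on; it does not show what in the cores accounts for the gap, and two pairs give no rule for any further core.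

The compounds shown leave open how a longer chain such as butyl, or a cyclopropyl or tert-butyl group, would behave on a double-bonded chain carbon bound to a double-bonded chain carbon on either core. They also leave open whether the step would hold its size on a third core, for instance one carrying an amine or a carboxylic acid.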